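Methylamino for methyl on the aryl ring of a pyridine amide

The compounds below may be only part of what the source reports. "The series", "measured", "known", "first", "only" and "open" are said of these compounds alone.

The series shares one amide core carrying a tetrazole, and the three measured compounds differ only in what sits on one aromatic carbon of the pyridine. In a functional assay on the whole organism for inhibition, with Rattus norvegicus as the target, at a dose of 0.3 mg/kg by the oral route (on this read-out higher numbers stand for a stronger effect at the one dose given and lower numbers for a weaker effect), compound 1 `Cc1ccc(-c2cc(Cl)cc(C(=O)Nc3nn[nH]n3)n2)cc1` gives 10%, compound 2 `CCOc1cc(C(=O)Nc2nn[nH]n2)nc(-c2ccc(C)cc2)c1` gives 26%, and compound 3 `Cc1ccc(-c2cccc(C(=O)Nc3nn[nH]n3)n2)cc1` gives 21%. Compound 3 stands second highest of the three: its nearest neighbour is compound 2, within the scatter, while compound 1 lies furthest, beyond the scatter. The steps seen so far, a number 16 percentage points higher from compound 1 to compound 2 (beyond the scatter), a number 11 percentage points higher from compound 1 to compound 3 (beyond the scatter) and a number 5 percentage points lower from compound 2 to compound 3 (within the scatter), all concern that pyridine position.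

Compound 4 `CNc1ccc(-c2cccc(C(=O)Nc3nn[nH]n3)n2)cc1` changes a different place: methylamino in place of methyl on an aromatic carbon. Among the compounds with values here, no measured step touches this ring, so nothing in the data points to a direction. It is therefore expected that the step of no change at the digits printed from compound 3 to compound 4 (within the scatter) stays within the scatter. The estimate for compound 4 in this assay is 21%, with a range from 5% to 40%.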

Compound 4, a percentage reported as inhibition, in the whole organism at one dose (the size of the read-out at that dose, not a potency): 29%
Compound 4: middle estimate off by 8 percentage points, on the low side; the measured number falls inside the stated range.
By their numbers in this assay, from the lowest: compound 1; then compounds 3, 2 and 4 (each within the scatter of the next).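

Within the data shown here, this is the first measured change on the six-membered aromatic ring of carbon only, away from the pyridine position varied in the earlier compounds. In this assay methylamino in place of methyl gives a number 8 percentage points higher from compound 3 to compound 4 (within the scatter), so this position takes a group carrying one hydrogen-bond donor and one hydrogen-bond acceptor, where methyl has neither, without a shift that can be told from the scatter. Nothing measured here bears on what lies behind this result.

On these data alone, whether an amino group, a dimethylamino group or a methoxy group at this carbon would read any differently remains open, as does whether methylamino would do the same alongside the ethoxy or chloro of the pyridine series. With only one dose, the potency of any of these compounds also stays unknown.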